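A few compounds are considered here, and "the series" means these few. Any claim that something is new, unique, unknown or untested is made for them only; others in the source may bear on it.

Measured compounds in the series:

compound 1, `Cc1nc(C)c(C(=O)Oc2ccccc2/C=C/C(=O)O)nc1C`: 45.7%
compound 2, `COc1ccc(/C=C/C(=O)O)c(OC(=O)c2nc(C)c(C)nc2C)c1`: 39.7%
compound 3, `COc1cc(/C=C/C(=O)O)ccc1OC(=O)c1nc(C)c(C)nc1C`: 38.7%

In a functional assay on EA.hy 926 cells (Homo sapiens) for cytotoxicity, read by MTT assay, with stated times of 24 h and 12 h, tested at 12.5 uM (a higher number here means a stronger effect of the compound at the concentration tested, a lower number a weaker effect), compound 1 stands highest of the three numbers, but its lead is slight: the nearest is compound 2, whose value is lower only within the scatter, and the furthest is compound 3, also within the scatter. No order among the three compounds can be read from these numbers; all three sit in one band.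

Compound 4, `COc1ccc(OC(=O)c2nc(C)c(C)nc2C)c(/C=C/C(=O)O)c1`, has not been measured yet. It differs from compound 1 by methoxy in place of hydrogen on an aromatic carbon. Going by the values given here, the one measured step of the same kind is a number 6 percentage points lower from compound 1 to compound 2 (within the scatter). Compound 3 likewise carries a methoxy on an aromatic carbon and gives a value close to that of compound 2. The data hold nothing that separates one placing of the methoxy from another, so the step to compound 4 is judged by the two methoxy compounds already in hand. The expected step is a small downward shift that stays within the scatter, a number 5.7 percentage points lower from compound 1 to compound 4 (within the scatter). Compound 4 is therefore expected to give 40%, with a likely range from 30% to 50%.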

Compound 4, a percentage reported as activity, at one concentration (the size of the read-out at that concentration, not a potency): 21.7%
Beside the measured number, compound 4's estimate is 18.3 percentage points above it; the measured number lies below the stated range.
By their numbers in this assay, from the lowest: compound 4; then compounds 3, 2 and 1 (each within the scatter of the next).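

In this assay, methoxy in place of hydrogen on an aromatic carbon now gives a step beyond the scatter, a number 24 percentage points lower from compound 1 to compound 4 (beyond the scatter), while the same kind of exchange in the earlier pair stayed within it, a number 6 percentage points lower from compound 1 to compound 2 (within the scatter). The exchange therefore has no single outcome in this series: its size depends on where the methoxy stands, and the placing meta to a 2-carboxyethenyl group and para to a large group is the one that goes with the clear drop, with compound 2 at 39.7%, compound 3 at 38.7% and compound 4 at 21.7%. Nothing in hand accounts for this dependence on placing.

Still open, going by these compounds, is whether the lower number belongs to methoxy itself or to any group at this position, a question that a hydroxyl, an amine or a longer chain such as ethoxy at the same carbon would address. Also open, on these data alone, is whether the drop seen at a single concentration would hold across a full concentration series, as the read-out here gives the size of an effect and not a potency.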